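Metabolic stability across amine substituents on the shared core

The source may hold more compounds than are shown below. What is called first, only, known or untested is meant among the compounds shown, and "the series" means these compounds.

Measured so far:
compound 1, `CCCS(=O)(=O)N1CC=C(c2ccc3c(c2)CC(C2CCN(C(=O)OC(C)C)CC2)O3)CC1`, 12%
compound 2, `CCCS(=O)(=O)N1CC=C(c2ccc3c(c2)CC(C2CCN(S(=O)(=O)CCC)CC2)O3)CC1`, "not determined" (no result reported)
compound 3, `CCCS(=O)(=O)N1CC=C(c2ccc3c(c2)CC(C2CCN(c4ncc(C5CC5)cn4)CC2)O3)CC1`, 3%

In an ADME assay (liver, Mus musculus) for metabolic stability, using microsomes, with a stated time of 10 min (a higher number here means that more of the compound is left, a lower number that less of the compound is left), compound 1 gives 12% and compound 3 gives 3%. Among the measured compounds shown here, the step of a number 9 percentage points lower from compound 1 to compound 3 (within the scatter) is the only measured step between two compounds differing in one place; it stays within the scatter, so these two compounds cannot be ordered against each other. For compound 2 this assay holds no number; compound 2 stands in the series without a result.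

Compound 4, `CCCS(=O)(=O)N1CC=C(c2ccc3c(c2)CC(C2CCN(c4ccc(C(F)(F)F)cn4)CC2)O3)CC1`, is not yet measured. It differs from compound 2 as follows: 5-(trifluoromethyl)pyridin-2-yl in place of propylsulfonyl on an amine nitrogen in a ring. For the measured compounds named here, no measured step bears directly on this exchange, since compound 2 has no value. The nearest guide is the pair compound 1 and compound 3, where a carbamate and an aryl group on the same amine nitrogen in a ring both gave low remaining percentages, and the step between them was within the scatter. On that basis the expectation for compound 4 in this assay is a low value in the same region, with no direction beyond the scatter to claim.

Compound 4 is expected to give about 6% in this assay, estimated to fall between 1% and 18%.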

Compound 4, percent of the compound remaining: 46%
The estimate for compound 4 lay 40 percentage points below the measured number; the measured number lies above the stated range.
By their numbers in this assay, from the lowest: compounds 3 and 1 (each within the scatter of the next); then compound 4.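

In this assay, the substituent on the amine nitrogen in a ring now gives a clear separation: 5-(trifluoromethyl)pyridin-2-yl in place of 5-cyclopropylpyrimidin-2-yl gives a number 43 percentage points higher from compound 3 to compound 4 (beyond the scatter), and the same group in place of isopropoxycarbonyl gives a number 34 percentage points higher from compound 1 to compound 4 (beyond the scatter). Compound 1 and compound 3 alone could not be ordered, so the position had shown no step beyond the scatter until now, and the exchange from compound 3 to compound 4 shows that an aromatic ring on this nitrogen does not by itself settle the read-out. Nothing available bears on why this exchange gives so large a step.

The step from compound 2 to compound 4 cannot be read, which leaves propylsulfonyl unplaced relative to the other groups on this nitrogen. On these data alone, the exchange from compound 3 to compound 4 alters both the aromatic ring and its substituent, so it remains open which of the two carries the step; 5-cyclopropylpyridin-2-yl and 5-(trifluoromethyl)pyrimidin-2-yl on the same nitrogen would separate them.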